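Extending the butyl chain of compound 3

A few compounds are considered here, and "the series" means these few. Any claim that something is new, unique, unknown or untested is made for them only; others in the source may bear on it.

In a functional assay, with stated times of 30 s and 6 min, in the presence of a further agent that is not named here (a lower number here means a stronger inhibitor, a higher number a weaker inhibitor), compound 1 (`COc1cc(O)c(C(C)=O)cc1Br`) gives 15600000 nM. Compound 2 (`CCOc1cc(OC)c(Br)cc1C(C)=O`) gives 37900000 nM, and compound 3 (`CCCCOc1cc(OC)c(Br)cc1C(C)=O`) gives 38200000 nM, which leaves compound 3 level with compound 2 and weaker than compound 1. Compound 4 (`CCCCCCOc1cc(OC)c(Br)cc1C(C)=O`) extends the chain of compound 3: ethyl in place of hydrogen on a saturated chain carbon, four bonds along the chain from an oxygen on an aromatic ring. Ethyl in place of hydrogen on the oxygen gave a 2.4-fold higher number from compound 1 to compound 2 (0.39 log units; beyond the scatter), and butyl there gave a 2.4-fold higher number from compound 1 to compound 3 (0.39 log units; beyond the scatter). Within the data shown here, the closest precedent is the chain extension that gave a 1.0-fold higher number from compound 2 to compound 3 (0.00 log units; within the scatter), so no change beyond the scatter is expected. The expected step is a 1.0-fold lower number from compound 3 to compound 4 (0.00 log units; within the scatter). Compound 4 is estimated at 38000000 nM, with an expected range of 18000000 nM to 80000000 nM.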

Compound 4, half-maximal inhibitory concentration: 34000000 nM
Compound 4: middle estimate off by 1.1-fold (0.05 log units), on the high side; low and high end bracket the measured number.
By their numbers in this assay, from the lowest: compound 1; then compounds 4, 2 and 3 (each within the scatter of the next).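

In this assay the chain on the oxygen can run out to hexyl without the numbers separating: the printed steps are a 1.1-fold lower number from compound 3 to compound 4 (0.05 log units; within the scatter) and a 1.1-fold lower number from compound 2 to compound 4 (0.05 log units; within the scatter), both within the scatter, so ethyl, butyl and hexyl are not told apart here. Among these compounds, the only step beyond the scatter remains the one from hydrogen on the oxygen, seen again as a 2.2-fold higher number from compound 1 to compound 4 (0.34 log units; beyond the scatter), and its size holds across all three chains. Nothing measured here accounts for this plateau. On these data alone, whether a longer chain, or a chain carrying an amine or a carboxylic acid, would move the number away from this level remains open.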